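Replacing a large group on the shared core with methyl

The source may report more compounds than this note shows. Statements on the series, on what has been measured and on what is new or still open speak of the compounds shown alone.

compound 1 `COc1ccc(C2=C(c3ccc(SC)cc3)CC3CCCN3C2=O)cc1OC(=O)CNC(=O)OC(C)(C)C`: 20000 nM
compound 2 `COc1ccc(C2=C(c3ccc(SC)cc3)CC3CCCN3C2=O)cc1OC(=O)C1CCCN1C(=O)OC(C)(C)C`: 10000 nM

Both values come from a functional assay on SW-620 cells (Homo sapiens) for cytotoxicity; a lower number here means a stronger inhibitor of growth, a higher number a weaker inhibitor of growth. Within the data shown here, compound 1 sits within the scatter of compound 2, the only other compound measured. Compound 3 `COc1ccc(C2=C(c3ccc(SC)cc3)CC3CCCN3C2=O)cc1C` keeps the core of compound 1 and differs in one place: one carbon atom in place of a group of 12 heavy atoms (7 carbon, 1 nitrogen, 4 oxygen; no ring), on an aromatic carbon. The entering methyl sits on an aromatic carbon, ortho to a methoxy group. Among the measured compounds shown here, the one measured step that bears on this is a 2.0-fold lower number from compound 1 to compound 2 (0.30 log units; within the scatter). For the measured compounds named here, that step swaps one large group for another on a carbonyl carbon, whereas compound 3 loses the large group altogether, and no measured compound shows that loss. No clear step in either direction can therefore be expected in this assay, and the range stays wide. The estimated step is a 1.7-fold lower number from compound 1 to compound 3 (0.22 log units; within the scatter). Compound 3 is expected at 12000 nM, with an estimated range from 3000 nM to 40000 nM.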

Compound 3, concentration for 50% growth inhibition: 500 nM
Estimate against measurement, compound 3: 24-fold (1.38 log units) above; measured number below the stated range.
By their numbers in this assay, from the lowest: compound 3; then compounds 2 and 1 (each within the scatter of the next).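

In this assay, the aromatic carbon ortho to a methoxy group proves far more sensitive than the earlier pair suggested. Exchanging one large group for another on the carbonyl carbon gave only a 2.0-fold lower number from compound 1 to compound 2 (0.30 log units; within the scatter), whereas putting methyl in place of the whole group of 12 heavy atoms on the aromatic carbon gives a 40-fold lower number from compound 1 to compound 3 (1.60 log units; beyond the scatter), so the shared core inhibits growth more strongly without that group. No measurement shown accounts for this step.

Since methyl is the only small group shown at this place, it remains open whether the step comes from the methyl itself or simply from losing the large group. A hydrogen, a hydroxyl group or an ethyl chain at the same carbon would help to separate these two readings.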